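Swapping the benzyl group on an antiproliferative compound

The compounds below may be only part of what the source reports. "The series", "measured", "known", "first", "only" and "open" are said of these compounds alone.

Values measured so far in a functional assay on HeLa cells (Homo sapiens) for antiproliferative activity, read by MTT assay, with a stated time of 48 h; a lower number here means a stronger inhibitor, a higher number a weaker inhibitor
- compound 1 `Fc1cccc(F)c1CSc1nnc(-c2cnccn2)o1` gives > 50000 nM as a limit of the assay, not a number
- compound 2 `Fc1ccccc1CSc1nnc(-c2cnccn2)s1` gives 32700 nM as a measured number
- compound 3 `Clc1cccc(CSc2nnc(-c3cnccn3)n2-c2ccccc2)c1` gives 13500 nM as a measured number

Only two of these results are true numbers, and compound 3 at 13500 nM has the lower one. Its nearest neighbour, compound 2 at 32700 nM on the scale, lies beyond the usual scatter of repeated measurements.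

The next molecule, compound 4 `Fc1ccc(CSc2nnc(-c3cnccn3)n2-c2ccccc2)c(F)c1`, changes one place of compound 3 (2,4-difluorophenyl in place of 3-chlorophenyl on a saturated chain carbon bound to a sulfur), with 2,4-difluorophenyl in place of 3-chlorophenyl on a saturated chain carbon bound to a sulfur.

Among the compounds with values here, no measured pair isolates this change, so the guide is thin. Compound 2 also carries fluorine on its benzyl group and reads 32700 nM on a different core, which hints weakly at a higher number. Compound 1 also carries fluorine there, and its > 50000 nM is a limit.

In this assay a small shift toward a higher number is expected, no larger than the usual scatter. The estimated step is a 1.5-fold higher number from compound 3 to compound 4 (0.17 log units; within the scatter) and remains uncertain. In this assay compound 4 is estimated at 20000 nM with an expected range of 7000 nM to 50000 nM as its likely span.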

Compound 4, half-maximal inhibitory concentration: 12500 nM
Estimate against measurement, compound 4: 1.6-fold (0.20 log units) above; the measured number falls inside the stated range.
By their numbers in this assay, from the lowest: compounds 4 and 3 (each within the scatter of the next); then compound 2. At a limit, above all of these: compound 1.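

In this assay, compound 3 and compound 4 are the first pair shown that differ in one place only, so they give the first direct reading of the group on a saturated chain carbon bound to a sulfur. Putting 2,4-difluorophenyl in place of 3-chlorophenyl there gives a 1.1-fold lower number from compound 3 to compound 4 (0.03 log units; within the scatter) and leaves the two compounds within the usual scatter of each other, even though the entering group carries a different halogen and a different number of halogens. This exchange therefore produces no readable change on this core, and nothing measured here offers a reason for that.

On these data alone, both groups in this pair are halogen-bearing phenyl rings, so it remains open whether an amine or a carboxylic acid on that ring would move the number beyond the scatter. As far as these compounds go, it also remains open whether a longer chain carrying the same ring would do so, or whether the same exchange would read the same way on another core.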